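Step from compound 3 to compound 4

A few compounds are considered here, and "the series" means these few. Any claim that something is new, unique, unknown or untested is made for them only; others in the source may bear on it.

Measured in a functional assay on HL-60 cells (Homo sapiens) for activation; a higher number here means that more compound is needed for the effect, a lower number that less compound is needed:
- compound 1 `CCCCCCCCCCCCNCC(N)CCN`: 631 nM
- compound 2 `CCCCCCCCCCCCNC(=O)C(N)CN`: 2510 nM
- compound 3 `CCCCCCCCCCCCNC(=O)[C@@H](N)CCC(N)=O`: 7940 nM

Compound 3 has the highest number of the three, and the values of compound 1 and compound 2 both lie lower. The next analogue, compound 4 `CCCCCCCCCCCCNC(=O)C(N)CCCN`, carries 1,4-diaminobutyl in place of 1-amino-3-carbamoylpropyl on a carbonyl carbon.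

The most relevant measured change at this place is a 3.2-fold higher number from compound 2 to compound 3 (0.50 log units; beyond the scatter), where 1-amino-3-carbamoylpropyl replaced 1,2-diaminoethyl. The other measured change, a 4.0-fold higher number from compound 1 to compound 2 (0.60 log units; beyond the scatter), was made on an amine nitrogen and bears on this step only loosely. Among the measured compounds shown here, no measured pair compares 1,2-diaminoethyl with 1,4-diaminobutyl directly.

Compound 4 shares with compound 2, at 2510 nM, a diamino group on the carbonyl carbon, so a value near that of compound 2 is expected in this assay. The expected change is a modest fall in the number, similar in size to the step that led to compound 3, and is estimated as a 3.6-fold lower number from compound 3 to compound 4 (0.56 log units; beyond the scatter). For compound 4 the estimated value is 2200 nM, with an expected range of 800 nM to 6300 nM.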

Compound 4, half-maximal effective concentration: 2510 nM
The estimate for compound 4 lay 1.1-fold (0.06 log units) below the measured number; measured number inside the range.
By their numbers in this assay, from the lowest: compound 1; then compounds 2 and 4 (each within the scatter of the next); then compound 3.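

In this assay the exchange of 1-amino-3-carbamoylpropyl for 1,4-diaminobutyl on a carbonyl carbon gives a 3.2-fold lower number from compound 3 to compound 4 (0.50 log units; beyond the scatter) and shows that the rise seen on going to the carbamoyl compound does not follow from chain length alone, since compound 4 keeps the four chain carbons of the group it replaces. Placing 2-aminoethyl in place of amino on the saturated chain carbon gives no change at the digits printed from compound 2 to compound 4 (within the scatter) and so shows that, across this pair, 1,2-diaminoethyl and 1,4-diaminobutyl cannot be told apart in this assay even though the two groups differ in chain length. Nothing available here explains either step.

The step from compound 3 to compound 4 also drops the one defined stereocentre, so the contribution of the swap of carbamoyl for amino cannot be separated from that of stereochemistry. Also open, going by these compounds, is whether a longer chain than 1,4-diaminobutyl stays level with compound 4 and where a carboxylic acid in place of the carbamoyl of compound 3 would fall.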